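From Ether to Amide on the Shared Core

A few compounds are considered here, and "the series" means these few. Any claim that something is new, unique, unknown or untested is made for them only; others in the source may bear on it.

Measured in a functional assay on MCF7 cells (Homo sapiens) for antiproliferative activity, read by MTT assay, with a stated time of 48 h; a higher number here means a weaker inhibitor, a lower number a stronger inhibitor:
- Compound 1 `CCN(CC)C/C1=C/C[C@](C)(CCC=C(C)C)/C=C/[C@@H](OC(=O)C=C(C)C)[C@](C)(O)/C=C/C1=O`: 130 nM
- Compound 2 `CC(C)=CCC[C@]1(C)/C=C/[C@@H](OC(=O)C=C(C)C)[C@](C)(O)/C=C/C(=O)/C(CN(C(C)C)C(C)C)=C\C1`: 780 nM
- Compound 3 `COCOC/C1=C/C[C@](C)(CCC=C(C)C)/C=C/[C@@H](OC(=O)C=C(C)C)[C@](C)(O)/C=C/C1=O`: 3120 nM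

Compound 3 has the highest number of the three, at 3120 nM, and is the weakest inhibitor among them. Compound 4 `CCN(CC)C(=O)/C1=C/C[C@](C)(CCC=C(C)C)/C=C/[C@@H](OC(=O)C=C(C)C)[C@](C)(O)/C=C/C1=O` differs from it as follows: diethylcarbamoyl in place of (methoxymethoxy)methyl on a double-bonded ring carbon. Diethylcarbamoyl stands in place of (methoxymethoxy)methyl on a double-bonded ring carbon.

Among the compounds with values here, two measured steps bear on this change: a 24-fold higher number from compound 1 to compound 3 (1.38 log units; beyond the scatter), and a 4.0-fold higher number from compound 2 to compound 3 (0.60 log units; beyond the scatter). Both exchange an amino group for methoxymethoxy on a saturated chain carbon, so the number responds to changes in this part of the molecule. Within the data shown here, no measured compound carries a carbamoyl, so these steps are only a rough guide. Compound 4 keeps the diethyl groups of compound 1, which gives 130 nM, so a modest step to a lower number is expected in this assay. The expected change is a 2.4-fold lower number from compound 3 to compound 4 (0.38 log units; beyond the scatter). For compound 4 the estimated value is 1300 nM, with an expected range from 300 nM to 5000 nM.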

Compound 4, half-maximal inhibitory concentration: 12100 nM
Compound 4: middle estimate off by 9.3-fold (0.97 log units), on the low side; measured number outside the range, above it.
By their numbers in this assay, from the lowest: compound 1; then compound 2; then compound 3; then compound 4.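

In this assay, diethylcarbamoyl on the double-bonded ring carbon gave the highest number of any group seen at this position, with a 3.9-fold higher number from compound 3 to compound 4 (0.59 log units; beyond the scatter), a 16-fold higher number from compound 2 to compound 4 (1.19 log units; beyond the scatter) and a 93-fold higher number from compound 1 to compound 4 (1.97 log units; beyond the scatter). The last of these steps keeps the two ethyl groups on nitrogen and still carries the largest change, so a diethyl-substituted nitrogen alone does not secure a low number here. Compound 4 also contains nitrogen yet stands above compound 3, which has none in this group, and no further data explain this result.

The compounds shown leave open how a smaller amine such as dimethylamino, or a ring amine such as piperidine, would behave on the same chain carbon. They also leave open whether a secondary amide or a carboxylic acid on the ring carbon would follow compound 4.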